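Swapping a five-membered ring on the chlorophenyl arm

The source may hold more compounds than are shown below. What is called first, only, known or untested is meant among the compounds shown, and "the series" means these compounds.

Measured compounds:
compound 1 `Cn1nc2c(=O)n(CC3(O)CCN(Cc4ccc(-c5ccco5)cc4Cl)CC3)cnc2c1-c1ccc(CNC(=O)C(F)(F)F)cc1` gives 2060 nM
compound 2 `Cn1nc2c(=O)n(CC3(O)CCN(Cc4ccc(-c5ccncc5)cc4Cl)CC3)cnc2c1-c1ccc(CN)cc1` gives 257 nM
compound 3 `Cn1nc2c(=O)n(CC3(O)CCN(Cc4ccc(-c5ccsc5)cc4Cl)CC3)cnc2c1-c1ccc(CN)cc1` gives 59.5 nM

In an assay on isolated protein for inhibition of ubiquitin carboxyl-terminal hydrolase 7 (Homo sapiens), with stated times of 30 min and 2 h (on this read-out lower numbers stand for stronger inhibition and higher numbers for weaker inhibition), compound 3 gives 59.5 nM, the lowest number of the three. Within the data shown here, the nearest is compound 2, and the move a 4.3-fold lower number from compound 2 to compound 3 (0.64 log units; beyond the scatter) is the only single-place step among the measured compounds; it shows that exchanging one five-membered aromatic ring for another on this aromatic carbon shifts the read-out by a modest but real amount. Among the measured compounds shown here, compound 1, which carries the same furan-2-yl ring that enters below but also a different end group on the benzylic amine, gives 2060 nM; no single step links it to compound 3, so its value only hints that this furan-bearing arm is compatible with weaker inhibition.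

Compound 4 `Cn1nc2c(=O)n(CC3(O)CCN(Cc4ccc(-c5ccco5)cc4Cl)CC3)cnc2c1-c1ccc(CN)cc1` differs from compound 3 in one place: furan-2-yl in place of thiophen-3-yl on an aromatic carbon. Given the size of the step from compound 2 to compound 3, a step of comparable or somewhat smaller size is expected, most likely toward a higher number; the expected change is a 2.5-fold higher number from compound 3 to compound 4 (0.40 log units; beyond the scatter). Compound 4 is therefore estimated at 150 nM in this assay, with a range from 50 nM to 500 nM.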

Compound 4, half-maximal inhibitory concentration: 18.1 nM
Beside the measured number, compound 4's estimate is 8.3-fold (0.92 log units) above it, outside the stated range (below it).
By their numbers in this assay, from the lowest: compound 4; then compound 3; then compound 2; then compound 1.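

Thiophen-3-yl and furan-2-yl have the same heavy-atom, donor and acceptor counts, yet this assay still separates them, with a 3.3-fold lower number from compound 3 to compound 4 (0.52 log units; beyond the scatter) at this position, para to a large group. The three rings now fall in one order, and the change from pyridin-4-yl to furan-2-yl gives a 14-fold lower number from compound 2 to compound 4 (1.15 log units; beyond the scatter) as the largest ring step shown. Compound 1 also carries furan-2-yl, so its weak value does not come from that ring: removing the (trifluoromethyl)carbonyl group from the amine nitrogen gives a 110-fold lower number from compound 1 to compound 4 (2.06 log units; beyond the scatter) with the ring unchanged.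

Still open, on these data alone, is whether the sulfur-to-oxygen exchange or the ring's attachment point accounts for the thiophen-3-yl to furan-2-yl step, which a furan-3-yl or thiophen-2-yl group could help separate. Nothing shown here explains why the rings fall in this order.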